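The source may hold more compounds than are shown below. What is called first, only, known or untested is meant among the compounds shown, and "the series" means these compounds.

This small set of three compounds shares one core and differs only in the aromatic ring carried on an aromatic nitrogen of that core. For compound 1 `CCNC(=O)c1cc(Oc2ccc(NC(=O)c3cc4cccnc4n(-c4ccc(Cl)cc4)c3=O)cc2)ccn1` the entry in a functional assay on U-87MG ATCC cells for antiproliferative activity against U-87 MG (Homo sapiens), read by MTT assay, with a stated time of 72 h (on this read-out lower numbers stand for stronger inhibition and higher numbers for weaker inhibition), reads "not determined" (no result reported), so compound 1 brings no number. Within the data shown here, compound 2 `CCNC(=O)c1cc(Oc2ccc(NC(=O)c3cc4cccnc4n(-c4ccc(OC)cc4)c3=O)cc2)ccn1` is the only member with a number: in this assay compound 2 gives 7210 nM, and since no other value exists, its standing is simply that of the sole measured entry. Compound 3 `CCNC(=O)c1cc(Oc2ccc(NC(=O)c3cc4cccnc4n(-c4ccc(Br)cc4F)c3=O)cc2)ccn1` is the next to be tested. It differs from compound 2 in one place, (4-bromo-2-fluorophenyl in place of 4-methoxyphenyl on an aromatic nitrogen). Among the measured compounds shown here, no pair of measured compounds shows what such a swap does, so the size of the step in this assay can only be guessed; a modest gain in potency, close to the edge of the usual scatter, seems the most plausible outcome, though no real change would be no surprise. On that basis compound 3 is expected to reach 4000 nM, within a range from 1500 nM to 12000 nM. That estimate means an expected step of a 1.8-fold lower number from compound 2 to compound 3 (0.26 log units; within the scatter).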

Compound 3, half-maximal inhibitory concentration: 10300 nM
Compound 3: middle estimate off by 2.6-fold (0.41 log units), on the low side; low and high end bracket the measured number.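

In this assay the swap on the aromatic nitrogen gives a 1.4-fold higher number from compound 2 to compound 3 (0.15 log units; within the scatter), so at this position 4-bromo-2-fluorophenyl and 4-methoxyphenyl cannot be told apart by this read-out. The two groups have the same number of heavy atoms, but the entering group carries fluorine and bromine in place of the oxygen-bearing methoxy group, and this exchange leaves the read-out within its usual scatter. No accompanying measurement speaks to why the two compounds match in this way.

On these data alone, it remains open whether a ring carrying an amine or a carboxylic acid, or a simple alkyl chain in place of the ring, would move the number beyond the scatter. The separate contributions of the fluorine and the bromine also remain unresolved.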